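The compounds below may be only part of what the source reports. "The series", "measured", "known", "first", "only" and "open" are said of these compounds alone.

Measured compounds:
compound 1, `O=C(/C=C/c1ccccc1)OCC1COCCOCCOCCOCCOCCO1` — 48000 nM
compound 2, `CC(C)=CC1C(C(=O)OCC2COCCOCCOCCOCCOCCO2)C1(C)C` — 63000 nM

In a functional assay on HeLa cells (Homo sapiens) for inhibition, read by sulforhodamine B assay, with a stated time of 48 h (on this read-out higher numbers stand for weaker inhibition of growth and lower numbers for stronger inhibition of growth), compound 2 gives the highest of the two numbers, and compound 1 lies within the scatter of it. Among the compounds with values here, the one measured step, a 1.3-fold higher number from compound 1 to compound 2 (0.12 log units; within the scatter), changed the group on the carbonyl carbon without a change beyond the scatter. Compound 3, `O=C(CCCCOc1ccccc1)OCC1COCCOCCOCCOCCOCCO1`, differs from compound 2 by 4-phenoxybutyl in place of 2,2-dimethyl-3-(2-methylprop-1-en-1-yl)cyclopropyl on a carbonyl carbon, again an exchange at that carbonyl carbon. Within the data shown here, since the only comparable step stayed within the scatter, no step beyond the scatter is expected in this assay, and compound 3 is estimated at 50000 nM, in a range from 15000 nM to 160000 nM, meaning an expected step of a 1.3-fold lower number from compound 2 to compound 3 (0.10 log units; within the scatter).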

Compound 3, concentration for 50% growth inhibition: > 100000 nM
Compound 3: a limit, no number (the forecaster's own chance of this, stated with the estimate: 20%); middle value at least 2.0-fold (0.30 log units) away from the limit.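

In this assay compound 3, carrying 4-phenoxybutyl on the carbonyl carbon, gives > 100000 nM, which is a limit of the assay and not a number. Within the data shown here, the exchange for 2-phenylethenyl gives an at least 2.0-fold higher number from compound 1 to compound 3 (0.31 log units; beyond the scatter), the first step at this position beyond the scatter, while the exchange for 2,2-dimethyl-3-(2-methylprop-1-en-1-yl)cyclopropyl gives an at least 1.5-fold higher number from compound 2 to compound 3 (0.20 log units; that floor lies within the scatter). On these data alone, both steps are floors, so their full size remains unknown. As far as these compounds go, whether a shorter chain ending in phenoxy, or an amine at the end of the chain, would give a number below that limit stays open.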